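The source may hold more compounds than are shown below. What is called first, only, known or untested is meant among the compounds shown, and "the series" means these compounds.

Measured compounds:
Compound 1 `CCCCCCCCCCCCCCCCCC(=O)Nc1nnc(S[C@@H]2O[C@H](COC(C)=O)[C@H](OC(C)=O)[C@H](OC(C)=O)[C@H]2OC(C)=O)s1` gives 31200 nM in a functional assay on DU-145 cells (Homo sapiens) for cytotoxicity, read by MTT assay, with a stated time of 24 h; a lower number here means a stronger inhibitor, a higher number a weaker inhibitor.
Compound 2 `CCCCCCCCCCCC(=O)Nc1nnc(S[C@@H]2O[C@H](CO)[C@H](O)[C@H](O)[C@H]2O)s1` gives "not active" (no number reported) in this assay.
Compound 3 `CCCCCC(=O)Nc1nnc(S[C@@H]2O[C@H](COC(C)=O)[C@H](OC(C)=O)[C@H](OC(C)=O)[C@H]2OC(C)=O)s1` gives "not active" (no number reported) in this assay.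

Of the three, only compound 1 carries a number in this assay, and that number is weak. Compound 2 stands without a single number in this assay; compound 3 is the other entry that likewise has no number. So the record places compound 2 among the compounds for which the assay reported no activity rather than a concentration, and nothing about compound 2 can be ranked against compound 1 beyond noting that compound 1 did yield a value.

Compound 4 `CCCCCC(=O)Nc1nnc(S[C@@H]2O[C@H](CO)[C@H](O)[C@H](O)[C@H]2O)s1` is the next compound to be measured in this assay. It differs from compound 2 in one place: hydrogen in place of hexyl on a saturated chain carbon, five bonds along the chain from a carbonyl carbon. Among the measured compounds shown here, no step between measured compounds is recorded that would show what this change does, and the nearest comparison, compound 3, also ended without a number. No step beyond the usual scatter is expected here in either direction; compound 4 is expected to remain at the inactive end, with an estimated value of 100000 nM, and a range of 40000 nM to 300000 nM if the assay reports a number at all.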

Compound 4, half-maximal inhibitory concentration: "not active" (no number reported)
No number was reported for compound 4, and the estimate cannot be compared.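

In this assay compound 4, like compound 2, was reported as not active without a number, so no new step can be read between them. The compounds shown leave open what the change from hexyl to hydrogen does in this cytotoxicity read-out. No available evidence bears on this result.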